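Swapping chloro for methoxy on a urea tail

A few compounds are considered here, and "the series" means these few. Any claim that something is new, unique, unknown or untested is made for them only; others in the source may bear on it.

Of the compounds shown here, three built around related cores have been measured in a functional assay on MDA-MB-231 cells (Homo sapiens) for antiproliferative activity, read by MTT assay, with a stated time of 72 h; on this read-out lower numbers stand for stronger inhibition and higher numbers for weaker inhibition. Compound 1 `CC(=O)Nc1ccc(S(=O)(=O)Nc2cccc(-c3nc(-c4ccc(NC(=O)c5cccnc5)cc4Cl)no3)c2)cc1` gives 2500 nM. Compound 2 `COc1cc(NC(=O)c2cccnc2)ccc1-c1noc(-c2cccc(NS(=O)(=O)c3ccc(NC(C)=O)cc3)c2)n1` is its partner with methoxy in place of chloro on an aromatic carbon. For compound 2 the result is a limit of the measurement, > 10000 nM, which is one of the values sitting at the limit of > 10000 nM in this assay, at which 1 of the 3 values shown sits. That step, an at least 4.0-fold higher number from compound 1 to compound 2 (0.60 log units; beyond the scatter), is a loss of potency. Compound 3 `O=C(Nc1cccc(-c2nc(-c3ccc(NC(=O)c4cccnc4)cc3Cl)no2)c1)Nc1ccc(Cl)c(C(F)(F)F)c1` gives 1900 nM; the difference between its core and the core of compound 1 is not broken down here, and their two values lie within the scatter of each other.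

Compound 4 `COc1ccc(NC(=O)Nc2cccc(-c3nc(-c4ccc(NC(=O)c5cccnc5)cc4Cl)no3)c2)cc1C(F)(F)F` is still to be measured. It carries the same kind of change as compound 2, methoxy in place of chloro on an aromatic carbon, but at a different place: in compound 2 the change sits ortho to a large group and meta to a ((pyridin-3-yl)carbonyl)amino group, while in compound 4 it sits ortho to a trifluoromethyl group and para to a large group.

Beside an at least 4.0-fold higher number from compound 1 to compound 2 (0.60 log units; beyond the scatter), the step expected here is smaller, a 2.4-fold higher number from compound 3 to compound 4 (0.37 log units; beyond the scatter), because an at least 4.0-fold higher number from compound 1 to compound 2 (0.60 log units; beyond the scatter) was measured at a different place and as a single prior case gives only weak guidance. Compound 4 is estimated at 4500 nM, between 1500 nM and 15000 nM.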

Compound 4, half-maximal inhibitory concentration: 1700 nM
Estimate against measurement, compound 4: 2.6-fold (0.42 log units) above; low and high end bracket the measured number.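

Going from the 4-chloro-3-(trifluoromethyl)phenyl tail to the 4-methoxy-3-(trifluoromethyl)phenyl tail in this assay gives a 1.1-fold lower number from compound 3 to compound 4 (0.05 log units; within the scatter), so on this tail the swap of chloro for methoxy produces no change that can be told from ordinary assay noise. Set beside the earlier pair, the same swap does not give the same result on the two cores, which is a warning against carrying the outcome of this change from one core to another in this series: the same change on two cores in this assay, an at least 4.0-fold higher number (0.60 log units; beyond the scatter) from compound 1 to compound 2 and a 1.1-fold lower number (0.05 log units; within the scatter) from compound 3 to compound 4, at least 4.4-fold (0.65 log units) apart, beyond the scatter of two such steps These two pairs alone cannot show what sets the cases apart, as the swap sits at a different place in each pair and the surrounding structure differs too, and the true size of the earlier step also stays unknown: compound 2 gives > 10000 nM, which is a limit of the assay and not a number.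

The compounds shown leave open whether the place of the swap or the rest of the core decides the outcome, which would take the same swap at the other place on each core to settle. They also leave open how a methyl group or an amine would fare where chloro and methoxy sit on the urea tail.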